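Swapping fluoro for nitro on a second lactone core

A few compounds are considered here, and "the series" means these few. Any claim that something is new, unique, unknown or untested is made for them only; others in the source may bear on it.

Two pairs of cinnamate esters built on a pyranone lactone are compared here. Compound 1 `O=C1C=C[C@@H](OCc2ccccc2)[C@@H]([C@@H](COC(=O)/C=C/c2ccc(F)cc2)OCc2ccccc2)O1` carries two benzyl ethers and a fluoro group, while compound 2 `O=C1C=C[C@@H](OCc2ccccc2)[C@@H]([C@@H](COC(=O)/C=C/c2ccc([N+](=O)[O-])cc2)OCc2ccccc2)O1` differs from it only by the change (nitro in place of fluoro on an aromatic carbon). In a functional assay on K562 cells (Homo sapiens) for antiproliferative activity, read by MTT assay, with a stated time of 6 days (a lower number here means a stronger inhibitor, a higher number a weaker inhibitor), compound 1 gives 1010 nM, and compound 2 gives 1270 nM; the step of a 1.3-fold higher number from compound 1 to compound 2 (0.10 log units; within the scatter) is too small to count as a real shift.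

Compound 3 `CC(=O)O[C@@H]1C=CC(=O)O[C@@H]1[C@@H](COC(=O)/C=C/c1ccc(F)cc1)OC(C)=O` keeps the fluoro-bearing cinnamate but has acetyl groups where compound 1 has benzyl ethers; how the two cores differ is not broken down here. In this assay, among the measured compounds shown here, compound 3 gives 3460 nM, the highest of the three numbers measured so far.

Compound 4 `CC(=O)O[C@@H]1C=CC(=O)O[C@@H]1[C@@H](COC(=O)/C=C/c1ccc([N+](=O)[O-])cc1)OC(C)=O` is made from compound 3 by the same change, (nitro in place of fluoro on an aromatic carbon), at the same place. Since the earlier step gave a 1.3-fold higher number from compound 1 to compound 2 (0.10 log units; within the scatter), a comparably small step is expected here, a 1.2-fold higher number from compound 3 to compound 4 (0.09 log units; within the scatter), resting only on that one precedent. Compound 4 is therefore estimated at 4300 nM, within 2000 nM to 9500 nM.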

Compound 4, half-maximal inhibitory concentration: 2340 nM
Compound 4: the middle estimate sits 1.8-fold (0.26 log units) above what was measured; the measured number falls inside the stated range.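

In this assay, the new step, a 1.5-fold lower number from compound 3 to compound 4 (0.17 log units; within the scatter), is as small as the earlier one, so on this core too, putting nitro in place of fluoro produces no change that can be told apart from the ordinary spread of repeat measurements. Set side by side, the two steps agree, and their opposite directions cannot be read as a real reversal: the same change on two cores in this assay, a 1.3-fold higher number (0.10 log units; within the scatter) from compound 1 to compound 2 and a 1.5-fold lower number (0.17 log units; within the scatter) from compound 3 to compound 4, 1.9-fold (0.27 log units) apart, within the scatter of two such steps. Among the compounds shown here, this shows that the swap made no readable difference on either of these two cores, but with only two pairs it does not show that the same would hold on any other core, and it does not explain why the number stays put.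

The compounds shown carry only fluoro or nitro at this place on the ring, so it remains open whether an amine or a carboxylic acid there would also leave the number unmoved. On these data alone, it also remains open whether the swap would stay this silent if a longer chain took the place of the acetyl groups.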